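This account rests on a few compounds, and the source may have more. Where it says the series, first, only, none or still open, it means among the compounds named here.

Measured compounds:
Compound 1 `Cc1cc(O)c(C(C)C)cc1-c1cc(-c2ccccc2)c(C#N)c(=O)[nH]1`: 22%
Compound 2 `COc1cccc(-c2cc(-c3cc(C(C)C)c(O)cc3C)[nH]c(=O)c2C#N)c1`: 22%
Compound 3 `Cc1cc(O)c(C(C)C)cc1-c1cc(-c2ccco2)c(C#N)c(=O)[nH]1`: 26%

In a functional assay for inhibition, tested at 20 ug/mL (on this read-out lower numbers stand for a weaker effect and higher numbers for a stronger effect at the one concentration tested), compound 1 gives 22%, level with compound 2 and together with it the lowest of the three numbers; the other two compounds are not separated from it beyond the scatter, as no change at the digits printed from compound 1 to compound 2 (within the scatter) and a number 4 percentage points higher from compound 1 to compound 3 (within the scatter) show. Compound 4 `Cc1cc(O)c(C(C)C)cc1-c1cc(-c2ccc(N(C)C)cc2)c(C#N)c(=O)[nH]1` differs from compound 1 in one place: dimethylamino in place of hydrogen on an aromatic carbon. The step that bears on this is no change at the digits printed from compound 1 to compound 2 (within the scatter), where a different small group entering the same phenyl left the read-out unchanged; the change of phenyl to furan-2-yl, a number 4 percentage points higher from compound 1 to compound 3 (within the scatter), was also within the scatter. On that basis no step beyond the scatter is expected, a number 2 percentage points higher from compound 1 to compound 4 (within the scatter). For compound 4 the estimated value is 24%, expected to lie between 10% and 40%.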

Compound 4, a percentage reported as inhibition, at one concentration (the size of the read-out at that concentration, not a potency): 30%
Compound 4: the middle estimate sits 6 percentage points below what was measured; low and high end bracket the measured number.
By their numbers in this assay, from the lowest: compounds 1, 2, 3 and 4 (each within the scatter of the next).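

In this assay, a dimethylamino group on the phenyl ring, para to a large group, gives a number 8 percentage points higher from compound 1 to compound 4 (within the scatter), so even this larger substituent does not separate compound 4 from the unsubstituted phenyl. Against the other two groups at this place, the change gives a number 4 percentage points higher from compound 3 to compound 4 (within the scatter) and a number 8 percentage points higher from compound 2 to compound 4 (within the scatter), so none of the four compounds can yet be told apart here. Nothing measured here points to a cause.

On these data alone, whether a carboxylic acid or a longer alkyl chain at this para place would produce a step beyond the scatter remains open.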